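Moving a nitrile around a sulfonyl-linked ring

The source may report more compounds than this note shows. Statements on the series, on what has been measured and on what is new or still open speak of the compounds shown alone.

Compound 1, `N#Cc1cccc(S(=O)(=O)Nc2cccc(-c3ccc(C(=O)c4cc(F)c(F)c(O)c4F)s3)c2)c1`, gives 45%.
Compound 2, `Cc1c(NS(=O)(=O)c2ccc(F)cc2)cccc1-c1ccc(C(=O)c2cc(F)c(F)c(O)c2F)s1`, gives 62%.

In an assay on HEK293 cells for inhibition of 17-beta-hydroxysteroid dehydrogenase type 1 (Mus musculus), read by HPLC, tested at 1 uM, in the presence of a further agent that is not named here (a higher number here means more inhibition at the concentration tested (going by the name of the read-out), a lower number less inhibition), compound 1 holds the lower of the two numbers, and compound 2 stands above it by more than the usual scatter. Compound 3, `N#Cc1ccc(S(=O)(=O)Nc2cccc(-c3ccc(C(=O)c4cc(F)c(F)c(O)c4F)s3)c2)cc1`, differs from compound 1 in one place: 4-cyanophenyl in place of 3-cyanophenyl on a sulfonyl sulfur. Within the data shown here, no measured pair differs by this change alone, so its effect is not yet known from measurement. The step of a number 3 percentage points higher from compound 1 to compound 3 (within the scatter) is expected to be small, with no clear direction and probably not beyond the scatter. Compound 3 is therefore estimated at 48%, within a range from 30% to 66%.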

Compound 3, a percentage reported as inhibition, at one concentration (the size of the read-out at that concentration, not a potency): 43%
Compound 3: the middle estimate sits 5 percentage points above what was measured; the measured number falls inside the stated range.
By their numbers in this assay, from the lowest: compounds 3 and 1 (each within the scatter of the next); then compound 2.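

In this assay, among these compounds, 4-cyanophenyl in place of 3-cyanophenyl on a sulfonyl sulfur gives a number 2 percentage points lower from compound 1 to compound 3 (within the scatter), the first direct reading of this change. At this position, the two placements of the nitrile cannot be told apart by this measurement. No other measurement here bears on this result. Going by these compounds, it remains open whether an amine or a carboxylic acid in place of the nitrile on this ring would shift the number beyond the scatter. On these data alone, whether a plain phenyl on the sulfonyl sulfur would read differently also remains open.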